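Acetamido to (Methoxycarbonyl)amino on a Shared Core

The source may report more compounds than this note shows. Statements on the series, on what has been measured and on what is new or still open speak of the compounds shown alone.

Of the compounds shown here, two have been measured in a functional assay on WI-38 VA13 cells (Homo sapiens) for cytotoxicity; on this read-out higher numbers stand for an effect only at larger amounts of compound and lower numbers for an effect already at smaller amounts. Compound 1 `CCC(C)(C)C(=O)Nc1ccc2nc(NC(=O)C3CCCCC3)sc2c1` gives 1 ug/mL in this assay. Compound 2 `CC(=O)Nc1nc2ccc(NC(=O)c3c(Cl)cccc3Cl)cc2s1` gives 0.6 ug/mL in this assay, and the gap between compound 1 and compound 2 lies within the usual scatter, so the two cannot be separated on the numbers alone. Compound 3 `COC(=O)Nc1nc2ccc(NC(=O)c3c(Cl)cccc3Cl)cc2s1` has not yet been measured. It differs from compound 2 in a single place: methoxy in place of methyl on a carbonyl carbon, which reads acetyl to methoxycarbonyl, or acetamido to (methoxycarbonyl)amino, when the cut is taken one bond further out. Among the measured compounds shown here, with no measured pair showing this change, the expected step from compound 2 to compound 3, a 1.2-fold higher number from compound 2 to compound 3 (0.07 log units; within the scatter), is small and not clearly beyond the scatter in either direction. Compound 3 is accordingly estimated at 0.7 ug/mL in this assay, within a range from 0.25 ug/mL to 2 ug/mL.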

Compound 3, half-maximal effective concentration: 0.0095 ug/mL
Compound 3: the middle estimate sits 74-fold (1.87 log units) above what was measured; measured number outside the range, below it.
By their numbers in this assay, from the lowest: compound 3; then compounds 2 and 1 (each within the scatter of the next).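

In this assay the change of methoxy in place of methyl on a carbonyl carbon gives a 63-fold lower number from compound 2 to compound 3 (1.80 log units; beyond the scatter) and so sets compound 3 clearly apart from compound 2. Compound 1 and compound 2 differ in more than one place and lie within the scatter of each other, so they gave no sign that this position could move the read-out so far, yet here a swap that adds one oxygen and one hydrogen-bond acceptor does so. No measurement at hand offers an explanation for the size of this step.

Going by these compounds, whether the oxygen itself matters remains open, since an ethoxy or a methylamino group on the same carbonyl carbon could separate it from other features of the change. Also open, on these data alone, is whether the same swap would produce a similar step on a compound with a different acyl group on the shared core.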